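This account rests on a few compounds, and the source may have more. Where it says the series, first, only, none or still open, it means among the compounds named here.

Measured so far in an ADME assay on PBMC cells (Homo sapiens) for cytotoxicity, with a stated time of 5 days; on this read-out higher numbers stand for weaker inhibition and lower numbers for stronger inhibition:
compound 1, `Cc1csc(C(=O)/C=C/c2ccc(N3CCCCC3)cc2)c1`: 68800 nM
compound 2, `O=C(/C=C/c1ccc(N2CCCCC2)cc1)c1ccc(Cl)s1`: > 100000 nM

In this assay compound 1 gives 68800 nM. For compound 2 this assay reports only a limit, > 100000 nM, and no number; this is the limit of > 100000 nM in this assay, at which 1 of the 2 values shown sits. The step of an at least 1.4-fold higher number from compound 1 to compound 2 (0.16 log units; that floor lies within the scatter) therefore carries only a floor. Compound 2 thus stands at the upper edge of the numbers shown, with no value resolved below the limit.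

Compound 3, `O=C(/C=C/c1ccc(N2CCCCC2)cc1)c1ccc(Br)s1`, differs from compound 2 by bromo in place of chloro on an aromatic carbon. For the measured compounds named here, the one measured step, an at least 1.4-fold higher number from compound 1 to compound 2 (0.16 log units; that floor lies within the scatter), concerns 5-chlorothiophen-2-yl in place of 4-methylthiophen-2-yl, a different exchange from bromo for chloro, so no measured step bears directly on the change at hand, and the one that exists has a floor within the scatter. The expected step is a step that the limit leaves unreadable from compound 2 to compound 3, that is none beyond the scatter. Compound 3 is accordingly estimated at 120000 nM, with a range from 55000 nM to 300000 nM, and is expected most likely to be reported in this assay again only as a limit rather than a number.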

Compound 3, half-maximal inhibitory concentration: > 100000 nM
Compound 3: only a limit was reported (the forecaster's own chance of this, stated with the estimate: 70%); the middle value is on the limit's open side.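

In this assay compound 3 gives > 100000 nM, which is a limit and not a number, so bromo in place of chloro on the aromatic carbon next to the ring sulfur yields a second compound at this limit. The comparison between compound 2 and compound 3 cannot be read, and any difference between chloro and bromo at this position stays hidden because both compounds sit at the same limit: the limit of > 100000 nM in this assay, at which 2 of the 3 values shown sit. The exchange of 4-methylthiophen-2-yl for 5-bromothiophen-2-yl gives an at least 1.4-fold higher number from compound 1 to compound 3 (0.16 log units; that floor lies within the scatter), so this exchange, like the one to 5-chlorothiophen-2-yl, stays unresolved from the scatter.

Open, on these data alone, is whether any group on this aromatic carbon brings the read-out back to a number in this assay, for instance an amine, a carboxylic acid or a nitrile in place of the bromo. Also open, as far as these compounds go, is whether the value of compound 1 follows from the methyl itself or from where it sits on the ring, a question that 5-methylthiophen-2-yl on the same core would address.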